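The compounds below may be only part of what the source reports. "The series", "measured", "known", "first", "only" and "open" are said of these compounds alone.

Three compounds share one core and differ only in what sits on the ring at the far end of the ethenyl link. In a functional assay on PC-3 cells (Homo sapiens) for antiproliferative activity, read by MTT assay, with a stated time of 72 h (on this read-out lower numbers stand for stronger inhibition and higher numbers for weaker inhibition), compound 1 `CC(C)(C)c1ccc(/C=C/C(=O)c2ccc(OCC(=O)N[C@H]3CCOC3=O)cc2)cc1` gives 10600 nM, compound 2 `CC(C)c1ccc(/C=C/C(=O)c2ccc(OCC(=O)N[C@H]3CCOC3=O)cc2)cc1` gives 4660 nM, and compound 3 `O=C(COc1ccc(C(=O)/C=C/c2ccccc2)cc1)N[C@H]1CCOC1=O` gives 56800 nM, the highest number of the three. The measured steps are a 2.3-fold lower number from compound 1 to compound 2 (0.36 log units; beyond the scatter), a 5.4-fold higher number from compound 1 to compound 3 (0.73 log units; beyond the scatter) and a 12-fold higher number from compound 2 to compound 3 (1.09 log units; beyond the scatter), so each removal of a branched alkyl group from the aromatic carbon raised the number. Compound 4 `O=C(COc1ccc(C(=O)/C=C/c2cccc(F)c2)cc1)N[C@H]1CCOC1=O` is compound 3 with fluoro in place of hydrogen on an aromatic carbon. Within the data shown here, the steps that bear on it involve hydrogen in place of tert-butyl or isopropyl, whereas here fluoro enters at a place meta to a large group; no measured pair shows such a change, so those steps bear on it only loosely. The account therefore expects no more than a modest move in this assay, if anything toward a lower number. For compound 4 the estimate is 35000 nM, between 12000 nM and 100000 nM. The expected step is a 1.6-fold lower number from compound 3 to compound 4 (0.21 log units; within the scatter).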

Compound 4, half-maximal inhibitory concentration: 23200 nM
Compound 4: the middle estimate sits 1.5-fold (0.18 log units) above what was measured; the measured number falls inside the stated range.
By their numbers in this assay, from the lowest: compound 2; then compound 1; then compound 4; then compound 3.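

In this assay, a single fluoro on an aromatic carbon, meta to a large group, already moves the number beyond the scatter (a 2.4-fold lower number from compound 3 to compound 4 (0.39 log units; beyond the scatter)), so the ring at the far end of the ethenyl link does not need a branched alkyl group for the number to fall. Fluoro at this place still does less than either alkyl group, as the steps to 3-fluorophenyl show (a 5.0-fold higher number from compound 2 to compound 4 (0.70 log units; beyond the scatter); a 2.2-fold higher number from compound 1 to compound 4 (0.34 log units; beyond the scatter)). No measurement at hand accounts for the effect of this change.

The compounds shown leave open whether chloro, methoxy or an amine at this same place would lower the number further, and what fluoro would do elsewhere on the ring. They also leave open whether fluoro and isopropyl on one ring would add up.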